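Ring size on the amine nitrogen of the shared core

The source may report more compounds than this note shows. Statements on the series, on what has been measured and on what is new or still open speak of the compounds shown alone.

Compound 3 `Cn1c(-c2ccccc2)nc2c(NC3CCC3)ncnc21` gives 3730 nM in a functional assay on CHO cells for antagonist activity at adenosine receptor A2b (Homo sapiens), read by 33P incorporation, with a stated time of 20 min (on this read-out lower numbers stand for stronger inhibition and higher numbers for weaker inhibition), the lowest of the two numbers shown. Compound 2 `Cn1c(-c2ccccc2)nc2c(NC3CCOC3)ncnc21` gives 13300 nM in this assay. For compound 1 `Cn1c(-c2ccccc2)nc2c(NC3CCCCC3)ncnc21` this assay reports only a limit, > 30000 nM (the limit of > 30000 nM in this assay, at which 1 of the 3 values shown sits). Compound 4 `Cn1c(-c2ccccc2)nc2c(NC3CCCC3)ncnc21` differs from compound 3 by cyclopentyl in place of cyclobutyl on a nitrogen on an aromatic ring. The measured steps that bear on this change are an at least 8.0-fold lower number from compound 1 to compound 3 (0.90 log units; beyond the scatter) and a 3.6-fold lower number from compound 2 to compound 3 (0.55 log units; beyond the scatter), both ending at cyclobutyl with lower numbers; an at least 2.2-fold lower number from compound 1 to compound 2 (0.35 log units; beyond the scatter) also went from a six-membered to a smaller ring with a lower number. The present change runs the other way, so a rise is expected, a 2.4-fold higher number from compound 3 to compound 4 (0.38 log units; beyond the scatter). Compound 4 is therefore estimated at 9000 nM, with a range from 3000 nM to 27000 nM.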

Compound 4, inhibition constant: 8510 nM
Compound 4: middle estimate off by 1.1-fold (0.02 log units), on the high side; low and high end bracket the measured number.
By their numbers in this assay, from the lowest: compound 3; then compounds 4 and 2 (each within the scatter of the next). At a limit, above all of these: compound 1.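

In this assay, the step from cyclobutyl to cyclopentyl gives a 2.3-fold higher number from compound 3 to compound 4 (0.36 log units; beyond the scatter), so one added ring carbon on the amine nitrogen is enough to move the number beyond the scatter. Cyclopentyl and oxolan-3-yl are not separated, with a 1.6-fold lower number from compound 2 to compound 4 (0.19 log units; within the scatter) lying within the scatter. The step of an at least 3.5-fold lower number from compound 1 to compound 4 (0.54 log units; beyond the scatter) rests on a limit and gives only a bound, so the carbon rings rise in order of size only as far as that bound allows: the limit of > 30000 nM in this assay, at which 1 of the 4 values shown sits.

Still open, on these data alone, is whether cyclopropyl would continue the fall in the number below cyclobutyl. Also open, as far as these compounds go, is how an open chain such as isopropyl, or a ring bearing a hydroxyl group, would behave at this nitrogen.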